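The source may report more compounds than this note shows. Statements on the series, on what has been measured and on what is new or still open speak of the compounds shown alone.

Measured in a functional assay on HepG2 cells (Homo sapiens) for antiproliferative activity, read by MTT assay, with a stated time of 72 h; on this read-out higher numbers stand for weaker inhibition and lower numbers for stronger inhibition:
- compound 1 `O=C(N/N=C/c1ccc(F)cc1)Nc1ccc(Oc2ccnc3[nH]ccc23)c(F)c1` gives 3880 nM
- compound 2 `O=C(N/N=C/c1ccccc1)Nc1ccc(Oc2ccnc3[nH]ccc23)cc1` gives 750 nM
- compound 3 `O=C(N/N=C/c1ccc(Br)cc1)Nc1ccc(Oc2ccnc3[nH]ccc23)cc1` gives 1000 nM

On these numbers compound 3 cannot be told apart from compound 2, while compound 1 stands beyond the scatter above both. Compound 4 `O=C(N/N=C/c1ccc(F)cc1)Nc1ccc(Oc2ccnc3[nH]ccc23)cc1` is compound 3 with one swap, fluoro in place of bromo on an aromatic carbon. For the measured compounds named here, the only measured step of this kind, bromo in place of hydrogen, was small (a 1.3-fold higher number from compound 2 to compound 3 (0.12 log units; within the scatter)). No step beyond the scatter is therefore expected in this assay. Compound 1 (3880 nM) also carries the 4-fluorophenyl, so the expected range stays wider on the high side. The expected change is small (a 1.1-fold lower number from compound 3 to compound 4 (0.05 log units; within the scatter)). The estimate for compound 4 is 900 nM (from 400 nM to 2200 nM).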

Compound 4, half-maximal inhibitory concentration: 3430 nM
For compound 4 the middle estimate is 3.8-fold (0.58 log units) below the measured one; the measured number lies above the stated range.
By their numbers in this assay, from the lowest: compounds 2 and 3 (each within the scatter of the next); then compounds 4 and 1 (each within the scatter of the next).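

In this assay the group on this aromatic carbon, para to a large group, proves to matter: fluoro gives a weaker result than bromo (a 3.4-fold higher number from compound 3 to compound 4 (0.54 log units; beyond the scatter)) and than hydrogen (a 4.6-fold higher number from compound 2 to compound 4 (0.66 log units; beyond the scatter)), although bromo and hydrogen could not be told apart. Taking away the second fluoro of compound 1 changes little (a 1.1-fold lower number from compound 1 to compound 4 (0.05 log units; within the scatter)), so compound 1 and compound 4, which share the 4-fluorophenyl, both stand at the weak end. Nothing available explains why fluoro differs from bromo here. Still open, going by these compounds, is whether chloro, methoxy or an amine on this carbon would behave like fluoro or like bromo and hydrogen.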